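This account rests on a few compounds, and the source may have more. Where it says the series, first, only, none or still open, it means among the compounds named here.

Compounds measured so far:
compound 1 `O=C1NC(c2ccccc2)=C([N+](=O)[O-])C(c2cccc([N+](=O)[O-])c2)N1` with 0.000045 mg/kg;
compound 2 `O=C1NC(c2ccccc2)=C([N+](=O)[O-])C(c2ccccc2)N1` with 0.035 mg/kg;
compound 3 `O=C1NC(c2ccccc2)=C([N+](=O)[O-])C(c2ccc(O)cc2)N1` with 0.035 mg/kg.

In an in vivo functional assay on the whole organism (heart) with Rattus norvegicus as the target (a lower number here means that less compound is needed, a higher number that more compound is needed for the effect), compound 1 stands at the lowest number of the three, far apart from the other two. Compound 4 `O=C1NC(c2ccccc2)=C([N+](=O)[O-])C(c2cccc(F)c2)N1` differs from compound 1 in one place: fluoro in place of nitro on an aromatic carbon. The step that bears most on this change is a 780-fold higher number from compound 1 to compound 2 (2.89 log units; beyond the scatter), where the nitro group was simply removed; the step of no change at the digits printed from compound 2 to compound 3 (within the scatter) shows that a small added hydroxy group changed nothing. A fluoro group seems closer to hydrogen than to nitro in this series, so a large rise is expected, perhaps a little short of that seen for compound 2. For compound 4 the expected result is 0.01 mg/kg, with a range of 0.001 mg/kg to 0.05 mg/kg, meaning an expected step of a 220-fold higher number from compound 1 to compound 4 (2.35 log units; beyond the scatter).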

Compound 4, minimum effective dose: 0.00035 mg/kg
Compound 4: middle estimate off by 29-fold (1.46 log units), on the high side, outside the stated range (below it).
By their numbers in this assay, from the lowest: compound 1; then compound 4; then compounds 2 and 3 (each within the scatter of the next).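

In this assay, a low number at this position does not depend on nitro: fluoro gives a 100-fold lower number from compound 2 to compound 4 (2.00 log units; beyond the scatter), which recovers much of the drop seen on removing nitro. Nitro still gives the lowest number, with a 7.8-fold higher number from compound 1 to compound 4 (0.89 log units; beyond the scatter). The comparison giving a 100-fold lower number from compound 3 to compound 4 (2.00 log units; beyond the scatter) swaps 4-hydroxyphenyl for 3-fluorophenyl, so it changes both the group and its place on the ring and cannot separate the two.

Nothing available here explains why these groups differ. On these data alone, whether chloro, methoxy or an amine in the same place would also give a low number remains open.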